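Swapping the Amide Aryl Group on a Shared Core

The source may hold more compounds than are shown below. What is called first, only, known or untested is meant among the compounds shown, and "the series" means these compounds.

Measured compounds:
Compound 1, `O=C(Nc1ccc(Cl)c(-c2nnc3c(Cl)cccn23)c1)c1ccccn1`: > 100000 nM in a functional assay on A549 cells (Homo sapiens) for antiproliferative activity, read by MTT assay, with a stated time of 72 h; a higher number here means a weaker inhibitor, a lower number a stronger inhibitor
Compound 2, `O=C(Nc1ccc(Cl)c(-c2nnc3c(Cl)cccn23)c1)c1ccon1`: 42700 nM in this assay

The value for compound 1 is a limit of this assay, not a number. Compound 2 sits at a measured number, and the change is an at least 2.3-fold lower number from compound 1 to compound 2 (0.36 log units; beyond the scatter). That the value for compound 1 is a limit is shown by the limit of > 100000 nM in this assay, at which 1 of the 2 values shown sits.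

The unmeasured compound is compound 3, `O=C(Nc1ccc(Cl)c(-c2nnc3c(Cl)cccn23)c1)c1ccccc1`. It differs from compound 1 by phenyl in place of pyridin-2-yl on a carbonyl carbon.

For the measured compounds named here, only one measured step exists, and it concerns a different replacement on the same carbonyl carbon, namely the one from compound 1 to compound 2; it does not involve phenyl. That step was at least modest, in the direction of a lower number. Going by the values given here, no step shows what phenyl does in place of pyridin-2-yl at this position, so the expectation rests on compound 1 alone, whose value is a limit.

For compound 3 the expected step is an at least 1.2-fold lower number from compound 1 to compound 3 (0.09 log units; that floor lies within the scatter), meaning little change beyond the scatter is anticipated. Compound 3 is therefore estimated at 80000 nM, with a range from 20000 nM to 300000 nM.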

Compound 3, half-maximal inhibitory concentration: 76900 nM
Beside the measured number, compound 3's estimate is 1.0-fold (0.02 log units) above it; low and high end bracket the measured number.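

Phenyl on the carbonyl carbon gives a second measured number at this position in this assay, so two groups can now be compared directly, and that comparison shows a 1.8-fold higher number from compound 2 to compound 3 (0.26 log units; within the scatter). Phenyl and 1,2-oxazol-3-yl therefore cannot be told apart here, which means that a measured number at this position is not unique to 1,2-oxazol-3-yl among the compounds shown. The third point concerns compound 1, whose value is a limit of the assay and not a number: the limit of > 100000 nM in this assay, at which 1 of the 3 values shown sits.

Against that limit, the change is an at least 1.3-fold lower number from compound 1 to compound 3 (0.11 log units; that floor lies within the scatter), so the true size of the swap from pyridin-2-yl to phenyl, which takes out the ring nitrogen, cannot be read, since only its floor is known and that floor does not clear the scatter. Still open, as far as these compounds go, is whether a group of another kind on this carbonyl carbon, such as a chain carrying an amine or a carboxylic acid, would move the number beyond the scatter from compound 3, and whether phenyl and 1,2-oxazol-3-yl would still match on a different core.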